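The compounds below may be only part of what the source reports. "The series", "measured", "known", "first", "only" and "open" are said of these compounds alone.

Measured compounds:
Compound 1 `CO/N=c1\[nH]cnc2c1[n+](Cc1ccccc1)cn2C` — in a functional assay on cells (Homo sapiens) for cytotoxicity (on this read-out higher numbers stand for weaker inhibition and lower numbers for stronger inhibition), compound 1 reaches only the limit > 80000 nM.
Compound 2 `CO/N=c1\[nH]cnc2c1[n+](C/C=C(\C)CC/C=C(\C)CC/C=C(\C)CCC=C(C)C)cn2C(C)C` — in this assay compound 2 gives 886 nM.
Compound 3 `C=CCn1c[n+](C/C=C(\C)CC/C=C(\C)CC/C=C(\C)CCC=C(C)C)c2/c(=N/OC)[nH]cnc21` — in this assay compound 3 gives 1250 nM.

Compound 3 stands at the highest of the two numbers, with compound 2 nearest; the change from compound 2 to compound 3, allyl in place of isopropyl on an aromatic nitrogen, gave a 1.4-fold higher number from compound 2 to compound 3 (0.15 log units; within the scatter). The value of compound 1 is a limit of the assay and not a number (the limit of > 80000 nM in this assay, at which 1 of the 3 values shown sits).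

Compound 4 `CO/N=c1\[nH]cnc2c1[n+](C/C=C(\C)CC/C=C(\C)CC/C=C(\C)CCC=C(C)C)cn2Cc1ccccc1` differs from compound 3 by phenyl in place of vinyl on a saturated chain carbon bound to an aromatic nitrogen. Among the measured compounds shown here, no measured pair shows this change: the only measured step, from compound 2 to compound 3, alters a different substituent and stays within the scatter, and compound 1, which carries a benzyl group, lacks the long chain and so shows only a limit. With nothing pointing either way, compound 4 is expected to stay close to compound 3, with the step of a 1.0-fold lower number from compound 3 to compound 4 (0.02 log units; within the scatter) expected to be none beyond the scatter. Compound 4 is estimated at 1200 nM, within a range from 450 nM to 3200 nM.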

Compound 4, half-maximal inhibitory concentration: 1040 nM
For compound 4 the middle estimate is 1.2-fold (0.06 log units) above the measured one, within the range that was stated.
By their numbers in this assay, from the lowest: compounds 2, 4 and 3 (each within the scatter of the next). At a limit, above all of these: compound 1.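

In this assay, the new result shows that a group carrying a phenyl ring is accommodated on the saturated chain carbon bound to an aromatic nitrogen without a change beyond the scatter: phenyl in place of vinyl gives a 1.2-fold lower number from compound 3 to compound 4 (0.08 log units; within the scatter), and benzyl in place of isopropyl gives a 1.2-fold higher number from compound 2 to compound 4 (0.07 log units; within the scatter). Earlier, only allyl and isopropyl could be set against each other; now isopropyl, allyl and benzyl all lie within the scatter of one another while the long chain stays the same. Nothing shown gives a reason for this sameness.

Going by these compounds, whether it holds for an amine or a carboxylic acid at this place remains open. Compound 1 gives only a limit, > 80000 nM, and differs from compound 4 in more than one place, so the contribution of the long chain cannot be read on its own.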